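Swapping the end group: from compound 2 to compound 3

A few compounds are considered here, and "the series" means these few. Any claim that something is new, unique, unknown or untested is made for them only; others in the source may bear on it.

Measured so far in a functional assay on Coronary artery (Bos taurus) (a higher number here means that more compound is needed for the effect, a lower number that less compound is needed), and still open
- compound 1 `CCCCCNC(=O)NCCCC/C=C\CCCCCNS(=O)(=O)c1ccccc1` gives 3400 nM
- compound 2 `CCCCCNC(=O)NCCCC/C=C\CCCCCS(=O)(=O)c1ncn[nH]1` gives 3100 nM
- compound 3 `CCCCCNC(=O)NCCCC/C=C\CCCCCCCc1nnn[nH]1` has no value yet

Compound 2 at 3100 nM sits level with compound 1 within the usual scatter, so neither can be ranked above the other. The change now in question is a group of 7 heavy atoms (3 carbon, 4 nitrogen; one five-membered aromatic ring with 4 hetero atoms) in place of a group of 8 heavy atoms (2 carbon, 3 nitrogen, 2 oxygen, 1 sulfur; one five-membered aromatic ring with 3 hetero atoms), on a saturated chain carbon, five bonds along the chain from a double-bonded chain carbon and it turns compound 2 into compound 3. The group that enters is 2-(1H-tetrazol-5-yl)ethyl. Going by the values given here, only one measured step bears on this, a swap at the same place: a 1.1-fold lower number from compound 1 to compound 2 (0.04 log units; within the scatter) and it stayed within the scatter. One step is thin evidence, but no step beyond the scatter is expected in this assay here. The expected step is a 1.6-fold lower number from compound 2 to compound 3 (0.19 log units; within the scatter) and it remains an estimate. Among the compounds with values here, for compound 3 the estimated value is 2000 nM with an expected range from 300 nM to 6000 nM and that range is wide, since no compound carrying this group has been measured yet.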

Compound 3, half-maximal effective concentration: 1100 nM
Estimate against measurement, compound 3: 1.8-fold (0.26 log units) above; measured number inside the range.
By their numbers in this assay, from the lowest: compound 3; then compounds 2 and 1 (each within the scatter of the next).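

In this assay, this place on the chain proves sensitive to the end group after all: 2-(1H-tetrazol-5-yl)ethyl gives a 2.8-fold lower number from compound 2 to compound 3 (0.45 log units; beyond the scatter) and a 3.1-fold lower number from compound 1 to compound 3 (0.49 log units; beyond the scatter), and both steps lie beyond the scatter, though both are modest. The earlier swap between compound 1 and compound 2 stayed within the scatter, so compound 3 now stands alone with the lowest number of the three, and its end group is the only one of the three without sulfur or oxygen. Nothing measured here accounts for this drop.

From the compounds shown here alone, the entering group differs from the leaving group in both its ring and its link to the chain, so it remains open which of the two carries the step. Going by these compounds, how a carboxylic acid or a longer chain ending in the same tetrazole ring would compare at this place also remains open.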